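The source may report more compounds than this note shows. Statements on the series, on what has been measured and on what is new or still open speak of the compounds shown alone.

Compound 1 `COc1cc(OC)c(OC)cc1/C=C/C(=O)c1cc(Cl)ccc1O` gives > 150000 nM in a functional assay on MCF7 cells (Homo sapiens) for inhibition, read by MTT assay, with a stated time of 72 h (a higher number here means a weaker inhibitor, a lower number a stronger inhibitor), a limit of the assay.
Compound 2 `COc1cc(OC)c(OC)cc1/C=C/C(=O)c1ccc(Cl)c([N+](=O)[O-])c1` gives 16400 nM in this assay.
Compound 3 `COc1cc(OC)c(OC)cc1/C=C/C(=O)c1cccc([N+](=O)[O-])c1` gives > 150000 nM in this assay, a limit of the assay.

Compound 1 stands at the limit, (the limit of > 150000 nM in this assay, at which 2 of the 3 values shown sit), so only a bound is known for it. Compound 4 `COc1cc(OC)c(OC)cc1/C=C/C(=O)c1ccc(F)cc1` arises from compound 1 by the change (4-fluorophenyl in place of 5-chloro-2-hydroxyphenyl on a carbonyl carbon). No measured step concerns this change; the only step shown, an at least 9.1-fold higher number from compound 2 to compound 3 (0.96 log units; beyond the scatter), removes a chloro elsewhere and does not carry over. With compound 1 known only as a limit, the direction of the step to compound 4 cannot be read from the data, and a modest, uncertain improvement is expected, an at least 3.7-fold lower number from compound 1 to compound 4 (0.57 log units; beyond the scatter). Compound 4 is therefore estimated at 40000 nM, within 8000 nM to 200000 nM.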

Compound 4, half-maximal inhibitory concentration: 30000 nM
Compound 4: the middle estimate sits 1.3-fold (0.12 log units) above what was measured; measured number inside the range.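

In this assay, exchanging 5-chloro-2-hydroxyphenyl for 4-fluorophenyl on a carbonyl carbon gives an at least 5.0-fold lower number from compound 1 to compound 4 (0.69 log units; beyond the scatter). The earlier step concerned only a chloro on an aromatic carbon, whereas this one shows that replacing the whole aryl group at the carbonyl carbon also brings the number off the limit. The true size of the step remains a bound: the limit of > 150000 nM in this assay, at which 2 of the 4 values shown sit.

The compounds shown leave open whether losing the hydroxy or changing the halogen carries this step. They also leave open how an amine or a carboxylic acid on this ring would compare.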